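The source may report more compounds than this note shows. Statements on the series, on what has been measured and on what is new or still open speak of the compounds shown alone.

Measured in a functional assay on CCRF-CEM cells (Homo sapiens) for cytotoxicity; a higher number here means that more compound is tolerated, a lower number that less compound is tolerated:

- Compound 1 `CCCC(=O)Nc1nc(N)nc2c1ncn2[C@H]1CO[C@@H](CO)O1`: > 100000 nM (a limit)
- Compound 2 `CCCCCCCC(=O)Nc1nc(N)nc2c1ncn2[C@H]1CO[C@@H](CO)O1`: > 100000 nM (a limit)
- Compound 3 `CCCCCCCCCCCC(=O)Nc1nc(N)nc2c1ncn2[C@H]1CO[C@@H](CO)O1`: 13000 nM

Compound 3 is the only one of the three with an actual number, since the other two values are limits. It therefore has no measured neighbour to be ranked against precisely. Compound 4 `CCCCCCCCCCCCCC(=O)Nc1nc(N)nc2c1ncn2[C@H]1CO[C@@H](CO)O1` is the next to be considered, and the change is ethyl in place of hydrogen on a saturated chain carbon, ten or more bonds along the chain from a carbonyl carbon. The chain thus grows further, with ethyl in place of hydrogen on a saturated chain carbon, ten or more bonds along the chain from a carbonyl carbon.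

The earliest step in the series, a step that the two limits leave unreadable from compound 1 to compound 2, gives no size. The steps that do bear on this one are an at least 7.6-fold lower number from compound 1 to compound 3 (0.88 log units; beyond the scatter) and an at least 7.6-fold lower number from compound 2 to compound 3 (0.88 log units; beyond the scatter). Both are minimum sizes set by a limit, and the second is the closer guide, since it also extends the chain far from the carbonyl carbon. It adds butyl, however, whereas compound 4 gains only ethyl. The same direction is therefore expected in this assay, but only a small move, and the expected change is a 2.2-fold lower number from compound 3 to compound 4 (0.34 log units; beyond the scatter).

Compound 4 is estimated at 6000 nM, with an expected range of 2000 nM to 18000 nM.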

Compound 4, half-maximal cytotoxic concentration: 4600 nM
Compound 4: the middle estimate sits 1.3-fold (0.12 log units) above what was measured; measured number inside the range.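

In this assay, among these compounds, a 2.8-fold lower number from compound 3 to compound 4 (0.45 log units; beyond the scatter) is the first step with a measured number at both ends, so the size of this change can now be read and is no longer only a minimum. It shows that the downward move continues past compound 3, and that adding just ethyl on a saturated chain carbon carries the number beyond the scatter. The wider steps, an at least 21-fold lower number from compound 2 to compound 4 (1.33 log units; beyond the scatter) and an at least 21-fold lower number from compound 1 to compound 4 (1.33 log units; beyond the scatter), are minimum sizes set by a limit: the limit of > 100000 nM in this assay, at which 2 of the 4 values shown sit.

As far as these compounds go, the step between the two compounds at the limit cannot be read, so where along the chain the number first starts to fall remains open. Also open, from the compounds shown here alone, are whether a longer chain would lower the number further or level it off, and what a chain carrying an amine or a carboxylic acid would give.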